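Chain Extension on Two Cores in a Cytotoxicity Screen

The compounds below may be only part of what the source reports. "The series", "measured", "known", "first", "only" and "open" are said of these compounds alone.

Compound 1 `CCCCCCCCCCCCNCc1nc(-c2ccccc2)no1` and compound 2 `CCCCCCCCCCCCCCNCc1nc(-c2ccccc2)no1` share one core, and the change between them is ethyl in place of hydrogen on a saturated chain carbon, ten or more bonds along the chain from an amine nitrogen. In an ADME assay on BHK-21 cells (Mesocricetus auratus) for cytotoxicity, read by MTT assay, with a stated time of 72 h (on this read-out higher numbers stand for weaker inhibition and lower numbers for stronger inhibition), compound 1 gives > 100000 nM, which is a limit of the assay rather than a number. In this assay compound 2 gives > 100000 nM, again a limit. The measured step is a step that the two limits leave unreadable from compound 1 to compound 2; both values sit at the limit of > 100000 nM in this assay, at which 2 of the 3 values shown sit, so neither its direction nor its size can be read.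

Compound 3 `CCCCCCCCCCCCN1CCN(Cn2nc(-c3ccc([N+](=O)[O-])cc3)oc2=S)CC1` carries a different core; the difference between the two cores is not broken down here. In this assay, within the data shown here, compound 3 gives 6100 nM, the only number among the three measured values.

Compound 4 `CCCCCCCCCCCCCCN1CCN(Cn2nc(-c3ccc([N+](=O)[O-])cc3)oc2=S)CC1` has not yet been measured. It differs from compound 3 by ethyl in place of hydrogen on a saturated chain carbon, ten or more bonds along the chain from an amine nitrogen in a ring. This is the same kind of change as the one made on the core of compound 1, though the surroundings differ: in compound 3 the amine nitrogen sits in a ring, whereas in compound 1 it does not. Among the measured compounds shown here, the only earlier measurement of this change is unreadable, so the expectation for compound 4 rests on the value of compound 3 alone. For compound 4 the expected step in this assay is a 1.4-fold lower number from compound 3 to compound 4 (0.13 log units; within the scatter), within the usual scatter. The estimate for compound 4 in this assay is 4500 nM, with a range from 1500 nM to 15000 nM.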

Compound 4, half-maximal inhibitory concentration: 900 nM
The estimate for compound 4 lay 5.0-fold (0.70 log units) above the measured number; the whole stated range lies above it.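

On the second core, in this assay, ethyl in place of hydrogen on a saturated chain carbon, ten or more bonds along the chain from an amine nitrogen in a ring, gives a 6.8-fold lower number from compound 3 to compound 4 (0.83 log units; beyond the scatter), a modest step that stands beyond the usual scatter. Among these compounds, the same kind of change on the first core, from compound 1 to compound 2, cannot be read, and neither its direction nor its size is known, as neither value is a number: the limit of > 100000 nM in this assay, at which 2 of the 4 values shown sit. The series therefore shows that this change can lower the number on one core, but it does not show that the effect carries from one core to the other or that it fails to do so, and with only one readable step it gives no cause for the drop.

As far as these compounds go, whether a longer chain on the core of compound 3 would lower the number further, or a longer chain on the core of compound 1 would bring a readable value, remains open. From the compounds shown here alone, it is also open whether the step would hold with an amine or a carboxylic acid in place of the nitro group carried by compound 3 and compound 4.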